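Adding a second bromo to compound 2

The source may report more compounds than this note shows. Statements on the series, on what has been measured and on what is new or still open speak of the compounds shown alone.

These are working notes on a small series read in an ADME assay on HEK293 cells (Homo sapiens) for cytotoxicity, read by reporter gene assay and resazurin assay, with a stated time of 48 h; on this read-out higher numbers stand for lower toxicity in this test and lower numbers for higher toxicity in this test. Compound 1 `COc1c(Br)cc(Br)cc1C(=O)Nc1ccc(Sc2nc3ccccc3s2)c(Cl)c1` gives > 100000 nM, which is a limit of the assay and not a number. Compound 2 `COc1c(Br)cccc1C(=O)Nc1ccc(Sc2nc3ccccc3s2)cc1` gives > 100000 nM, again a limit and not a number. Compound 2 therefore stands where the whole set stands, at the limit of > 100000 nM in this assay, at which 2 of the 2 values shown sit. Among the compounds with values here, no measured step joins the two compounds, so no single structural change has a size on record yet.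

Compound 3 `COc1c(Br)cc(Br)cc1C(=O)Nc1ccc(Sc2nc3ccccc3s2)cc1` comes from compound 2 by one edit: bromo in place of hydrogen on an aromatic carbon. This puts bromo in place of hydrogen on an aromatic carbon, para to a methoxy group.

No step beyond the scatter is expected in this assay, in either direction, because compound 2 reads the limit > 100000 nM. The expected size is a number no higher from compound 2 to compound 3 (the limit leaves the size open), which would stay within the scatter. A report of only a limit is the most likely outcome. For compound 3 the estimate is 100000 nM, with an expected range from 50000 nM to 200000 nM.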

Compound 3, half-maximal cytotoxic concentration: > 100000 nM
Compound 3: no number, only a limit (the forecaster's own chance of this, stated with the estimate: 90%); the middle value sits exactly at the limit.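

In this assay compound 3 gives > 100000 nM, a limit and not a number. No step can be read from compound 2 to compound 3 or from compound 1 to compound 3, as all three compounds share one reading: the limit of > 100000 nM in this assay, at which 3 of the 3 values shown sit.

The compounds shown leave open the size and direction of any effect of the bromo and chloro edits on half-maximal cytotoxic concentration.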